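This account rests on a few compounds, and the source may have more. Where it says the series, first, only, none or still open, it means among the compounds named here.

In an ADME assay on microsomes from liver (Mus musculus, strain CD-1) for metabolic stability, read by LC-MS, tested at 2 uM (on this read-out higher numbers stand for a longer-lived compound and lower numbers for a shorter-lived compound), compound 1 `Cn1cc(NC(=O)c2ccncc2Nc2cc(-c3ccc4ccn(C)c4c3)c3nccnc3c2)cn1` gives 0.2 h. Compound 2 `CN1CCC(NC(=O)c2ccncc2Nc2cc(-c3ccc4ccn(C)c4c3)c3nccnc3c2)CC1` gives > 1 h, which is a limit of the assay and not a number. Compound 2 is therefore bounded on one side only, with the limit of > 1 h in this assay, at which 1 of the 2 values shown sits.

The next change leads to compound 3 `Cn1ccc2ccc(-c3cc(Nc4cnccc4C(=O)NC4CCNC(=O)C4)cc4nccnc34)cc21`, which has not yet been measured in this assay: 2-oxopiperidin-4-yl in place of 1-methylpiperidin-4-yl on an amide-type nitrogen. In words, 2-oxopiperidin-4-yl stands in place of 1-methylpiperidin-4-yl on an amide-type nitrogen, so a six-membered non-aromatic ring is kept at this place.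

Among the compounds with values here, only one measured step bears on this change, an at least 5.0-fold higher number from compound 1 to compound 2 (0.69 log units; beyond the scatter). It was made at the same place, but it replaced 1-methyl-1H-pyrazol-4-yl, so it shows that this place can move the half-life and does not give the size of the new change. With a six-membered non-aromatic ring on both sides of the new change, no step beyond the scatter is expected, in either direction. The expected step is a number no higher from compound 2 to compound 3 (the limit leaves the size open). For compound 3 the estimate is 1 h, with an expected range from 0.4 h to 2.5 h.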

Compound 3, half-life: > 1 h
Compound 3: a limit, no number; the forecaster's own chance of this, stated with the estimate: 50%; the middle value lies on the limit itself.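

In this assay compound 3 gives > 1 h, which is a limit of the assay and not a number. Placing 2-oxopiperidin-4-yl on the amide-type nitrogen in place of 1-methyl-1H-pyrazol-4-yl gives an at least 5.0-fold higher number from compound 1 to compound 3 (0.69 log units; beyond the scatter), so a second six-membered non-aromatic ring now shows a clear gain in half-life, although it carries an oxo group and lacks the methyl of 1-methylpiperidin-4-yl. The step between compound 2 and compound 3 cannot be read, which leaves these two without an order, and the series now presses against the top of the measurable range: the limit of > 1 h in this assay, at which 2 of the 3 values shown sit.

From the compounds shown here alone, how far the half-life of either ring extends, and whether the two differ at all, remains open in this read-out. Also open, going by these compounds, is how a piperidin-4-yl group without the methyl or oxo group, or an open-chain aminoalkyl group, would behave on the amide-type nitrogen, which would show whether the gain over compound 1 depends on a six-membered non-aromatic ring at this place.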